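The compounds below may be only part of what the source reports. "The series", "measured", "known", "first", "only" and "open" are said of these compounds alone.

In a functional assay on the whole organism for inhibition, with Mus musculus as the target (a higher number here means that more compound is needed for the effect, a lower number that less compound is needed), compound 1 `CCOC(=O)Nc1cccc2c1CN(C)CC2c1ccc(F)cc1` gives 3.5 mg/kg and compound 2 `CCNCC(=O)Nc1cccc2c1CN(C)CC2c1ccccc1` gives 47 mg/kg. Among the measured compounds shown here, compound 2 therefore holds the higher of the only two numbers so far, and its gap to compound 1 lies beyond the scatter. For the measured compounds named here, these two compounds differ in more than one place, so the gap cannot be assigned to a single change, and no measured step bears directly on the next one.

Compound 3 `CCCCNCCC(=O)Nc1cccc2c1CN(C)CC2c1ccccc1` has not yet been measured. It departs from compound 2 by (butylamino)methyl in place of ethylamino on a saturated chain carbon bound to a carbonyl carbon, with (butylamino)methyl in place of ethylamino on a saturated chain carbon bound to a carbonyl carbon. Going by the values given here, with no step to guide it, the expectation is weak. The expected change, a 1.2-fold lower number from compound 2 to compound 3 (0.07 log units; within the scatter), is estimated to stay within the scatter, with no firm direction. For compound 3 the estimate is 40 mg/kg, with an expected range of 14 mg/kg to 110 mg/kg.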

Compound 3, dose for half-maximal effect: about 46 mg/kg
The estimate for compound 3 lay 1.2-fold (0.06 log units) below the measured number; measured number inside the range.
By their numbers in this assay, from the lowest: compound 1; then compounds 3 and 2 (each within the scatter of the next).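

In this assay, among the compounds shown here, the first readable step at this position is the exchange of ethylamino for (butylamino)methyl on a saturated chain carbon bound to a carbonyl carbon, which gives a 1.0-fold lower number from compound 2 to compound 3 (0.01 log units; within the scatter) for this pair. At this place, then, the larger amine-bearing chain leaves the number within the scatter, so this single exchange offers no handle on the dose needed for the effect. No measurement of any property bears on this result.

The compounds shown leave open whether a tertiary amine such as dimethylamino, a piperidine or a carboxylic acid at this place would separate from compound 2 beyond the scatter. The gap to compound 1 also stays unassigned, as compound 1 differs from compound 2 and compound 3 in more than one place.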